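The source may hold more compounds than are shown below. What is called first, only, known or untested is meant among the compounds shown, and "the series" means these compounds.

Working notes on the series in a functional assay on CHO cells for agonist activity at Free fatty acid receptor 1 (Homo sapiens), read by FLIPR, tested at 100 nM; a higher number here means a stronger effect of the compound at the concentration tested, a lower number a weaker effect.

Compound 1 `CCOc1ccccc1OC(C)C(=O)Nc1ccc(OCC(=O)O)c(F)c1` and compound 2 `Cc1ccc(OC(C)C(=O)Nc2ccc(OCC(=O)O)c(F)c2)cc1C` share one core and differ only in the aryl group on the oxygen on the saturated carbon. In this assay compound 1 gives 8.79%, and compound 2 gives 36.8%. Within the data shown here, the single step available, a number 28 percentage points higher from compound 1 to compound 2 (beyond the scatter), follows the exchange of 2-ethoxyphenyl for 3,4-dimethylphenyl. Among the measured compounds shown here, on the two numbers seen, compound 2 stands highest, with compound 1 the only neighbour.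

Compound 3 `Cc1cc(C)cc(OC(C)C(=O)Nc2ccc(OCC(=O)O)c(F)c2)c1` is the next member. Its change from compound 2 is 3,5-dimethylphenyl in place of 3,4-dimethylphenyl on an oxygen on a saturated carbon. For the measured compounds named here, this is a rearrangement of the same atoms, and no measured step covers such a move between two dimethylphenyl patterns; the one step in hand, from an ethoxy-bearing aryl to a dimethyl-bearing one, does not bear on it directly. With no guide either way, the step from compound 2 to compound 3 is expected to be small and possibly within the scatter, estimated as a number 6.8 percentage points lower from compound 2 to compound 3 (within the scatter). For compound 3 the value in this assay is therefore estimated at 30%, within a range from 10% to 50%.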

Compound 3, a percentage reported as activity, at one concentration (the size of the read-out at that concentration, not a potency): 25.7%
Beside the measured number, compound 3's estimate is 4.3 percentage points above it, and the stated range covers the measured number.
By their numbers in this assay, from the lowest: compound 1; then compound 3; then compound 2.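

In this assay, exchanging 3,4-dimethylphenyl for 3,5-dimethylphenyl on the oxygen on the saturated carbon keeps the same atoms, joined differently, yet the arrangement alone gives a number 11.1 percentage points lower from compound 2 to compound 3 (beyond the scatter), so this position distinguishes between two dimethylphenyl patterns and not only between ethoxy-bearing and dimethyl-bearing aryl groups. The second dimethylphenyl pattern also gives a number 16.9 percentage points higher from compound 1 to compound 3 (beyond the scatter), so among these three compounds both dimethylphenyl groups stand above 2-ethoxyphenyl, with no compound going against that order. No measurement at hand accounts for either step or for the difference between the two methyl patterns.

The compounds shown leave open whether the low number of compound 1 belongs to the ethoxy group itself or to its placement, a question that 3-ethoxyphenyl or 4-ethoxyphenyl would address directly. Also open, going by these compounds, is how this position responds to groups of a different kind, such as a 3,5-dichlorophenyl, a phenyl carrying an amine or a phenyl carrying a longer chain such as butyl, and whether the order of the three compounds would hold at other concentrations.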